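This account rests on a few compounds, and the source may have more. Where it says the series, first, only, none or still open, it means among the compounds named here.

Working notes on the series.

Compound 1 `C/C(=N\NC(=O)c1ccc(C(F)(F)F)cc1)c1cnccn1` carries a trifluoromethyl group and in an ADME assay on cells (Homo sapiens) for antiproliferative activity, read by MTT assay (on this read-out lower numbers stand for stronger inhibition and higher numbers for weaker inhibition), compound 1 gives 1160 nM. Compound 3 `C/C(=N\NC(=O)c1ccc(Br)cc1)c1cnccn1` is its counterpart with bromo in place of trifluoromethyl on an aromatic carbon, and in this assay compound 3 gives 1220 nM. The step is a 1.1-fold higher number from compound 1 to compound 3 (0.02 log units; within the scatter), so the two halides sit together on this read-out.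

Compound 2 `O=C(NN=C(c1ccccn1)c1ccccn1)c1ccc(C(F)(F)F)cc1` has a different core; the difference between the cores of compound 1 and compound 2 is not broken down here. In this assay compound 2 gives 240 nM, the lowest number of the three measured compounds, and its steps to compound 1 and compound 3 lie beyond the scatter.

Compound 4 `O=C(NN=C(c1ccccn1)c1ccccn1)c1ccc(Br)cc1` is still unmeasured. It differs from compound 2 by bromo in place of trifluoromethyl on an aromatic carbon, the same change as from compound 1 to compound 3, at a place described in the same words.

Because the measured step of a 1.1-fold higher number from compound 1 to compound 3 (0.02 log units; within the scatter) stays within the scatter, the expected step from compound 2 to compound 4 in this assay is a 1.1-fold higher number from compound 2 to compound 4 (0.03 log units; within the scatter). For compound 4 the estimated value in this assay is 260 nM, expected to fall between 130 nM and 520 nM.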

Compound 4, half-maximal inhibitory concentration: 300 nM
Compound 4: middle estimate off by 1.2-fold (0.06 log units), on the low side; the range from low to high includes it.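

In this assay, putting bromo in place of trifluoromethyl on the core of compound 2 gives a 1.3-fold higher number from compound 2 to compound 4 (0.10 log units; within the scatter), and the same change has now been read on two cores: the same change on two cores in this assay, a 1.1-fold higher number (0.02 log units; within the scatter) from compound 1 to compound 3 and a 1.3-fold higher number (0.10 log units; within the scatter) from compound 2 to compound 4, 1.2-fold (0.08 log units) apart, within the scatter of two such steps. On these two cores the change stays within the scatter each time, and the two steps agree, so in this small set it carries from one core to the other without a visible shift in the read-out. Among the compounds shown here, this does not show that the change would stay as small on a third core, it rests on only two pairs in a single assay, and it gives no reason why the two groups read alike.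

The compounds shown leave open how other groups, such as an amine, a carboxylic acid or a nitrile, would read at the same place on the aromatic ring. Also open, as far as these compounds go, is whether a plain hydrogen there would read like trifluoromethyl and bromo on either core.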